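This account rests on a few compounds, and the source may have more. Where it says the series, first, only, none or still open, it means among the compounds named here.

Of the compounds shown here, two have so far been measured in a functional assay on MCF7 cells (Homo sapiens) for cytotoxicity, read by colorimetric assay and sulforhodamine B assay, with a stated time of 48 h; on this read-out lower numbers stand for stronger inhibition and higher numbers for weaker inhibition. Compound 2 `COc1ccc(/C=N/n2c(C)nc3c(cnn3S(=O)(=O)c3ccc(Cl)cc3)c2=O)cc1OC` gives 33600 nM, the highest of the two numbers; compound 1 `COc1cc(/C=N/n2c(C)nc3c(cnn3-c3ccc(Cl)cc3)c2=O)cc(OC)c1OC` gives 7600 nM, a lower number, and the gap between the two lies beyond the usual scatter. These two differ in more than one place, so no single step can be read from them. Compound 3 `COc1cc(/C=N/n2c(C)nc3c(cnn3S(=O)(=O)c3ccc(Cl)cc3)c2=O)cc(OC)c1OC` carries methoxy in place of hydrogen on an aromatic carbon relative to compound 2. Among the compounds with values here, no measured pair shows this change on its own. Compound 3 is expected to give a somewhat lower number, with a 1.7-fold lower number from compound 2 to compound 3 (0.23 log units; within the scatter) estimated to lie near the edge of the scatter. In this assay compound 3 is estimated at 20000 nM, expected to fall between 7000 nM and 50000 nM.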

Compound 3, half-maximal inhibitory concentration: 27800 nM
Compound 3: the middle estimate sits 1.4-fold (0.14 log units) below what was measured, and the stated range covers the measured number.
By their numbers in this assay, from the lowest: compound 1; then compounds 3 and 2 (each within the scatter of the next).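

In this assay, methoxy in place of hydrogen on this aromatic carbon, ortho to a methoxy group and meta to a large group, gives a 1.2-fold lower number from compound 2 to compound 3 (0.08 log units; within the scatter), so this change alone shows no clear effect here. Compound 3 also isolates the group on the aromatic nitrogen: (4-chlorophenyl)sulfonyl in place of 4-chlorophenyl gives a 3.7-fold higher number from compound 1 to compound 3 (0.56 log units; beyond the scatter). Nothing available explains either step. From the compounds shown here alone, whether an amine or an ethoxy group on this aromatic carbon would behave like methoxy remains open, as does whether the step at the aromatic nitrogen holds with other groups on the shared core.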